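Replacing a Benzyl Group with a Sulfonyl Group

The source may hold more compounds than are shown below. What is called first, only, known or untested is meant among the compounds shown, and "the series" means these compounds.

Compound 1 `COC(=O)c1ccc(C2SCC(=O)N2c2ccc(N3CCN(Cc4cccc([N+](=O)[O-])c4)CC3)cn2)c(OC)c1` and compound 2 `COC(=O)c1ccc(C2SCC(=O)N2c2ccc(N3CCN(Cc4ccc(Cl)c(Cl)c4)CC3)cn2)c(OC)c1` share one core and differ only in the group on the ring nitrogen. In a functional assay on K562 cells (Homo sapiens) for antiproliferative activity, read by MTT assay and trypan blue exclusion, with a stated time of 72 h (on this read-out higher numbers stand for weaker inhibition and lower numbers for stronger inhibition), compound 1 gives 68700 nM. Compound 2 reaches only the limit of the assay, > 100000 nM, so no number is known for it. Within the data shown here, that limit is the one at which compound 2 sits (the limit of > 100000 nM in this assay, at which 1 of the 2 values shown sits). The step of an at least 1.4-fold higher number from compound 1 to compound 2 (0.16 log units; that floor lies within the scatter) therefore has a floor that lies within the scatter, and the two values cannot be ordered against each other.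

Compound 3 `COC(=O)c1ccc(C2SCC(=O)N2c2ccc(N3CCN(S(=O)(=O)c4c(C)cc(C)cc4C)CC3)cn2)c(OC)c1` has not yet been measured in this assay. It differs from compound 2 by (2,4,6-trimethylphenyl)sulfonyl in place of 3,4-dichlorobenzyl on an amine nitrogen in a ring. Among the measured compounds shown here, no measured step involves this kind of exchange; the only step seen, an at least 1.4-fold higher number from compound 1 to compound 2 (0.16 log units; that floor lies within the scatter), trades one benzyl group for another. The starting point for compound 3 is thus itself an open-ended limit. For compound 3 no movement beyond the scatter is expected, with a number no higher from compound 2 to compound 3 (the limit leaves the size open) as the working expectation. Compound 3 is estimated at 100000 nM, with a range from 30000 nM to 300000 nM.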

Compound 3, half-maximal inhibitory concentration: 53500 nM
Compound 3: middle estimate off by 1.9-fold (0.27 log units), on the high side; the range from low to high includes it.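

Compound 3 is the first compound shown with a sulfonyl group rather than a benzyl group on the amine nitrogen of the ring, and in this assay it gives a measured number rather than a limit. Set against the 3-nitrobenzyl group of compound 1, the exchange gives a 1.3-fold lower number from compound 1 to compound 3 (0.11 log units; within the scatter), so in this pair, the change from a benzyl group to (2,4,6-trimethylphenyl)sulfonyl does not separate the two compounds on this read-out. The step of an at least 1.8-fold lower number from compound 2 to compound 3 (0.27 log units; that floor lies within the scatter) offers only a floor, and compound 2 remains a limit of the assay, not a number: the limit of > 100000 nM in this assay, at which 1 of the 3 values shown sits.

The compounds shown leave open whether the sulfonyl link or the 2,4,6-trimethylphenyl ring accounts for the value of compound 3, a question that a plain phenylsulfonyl or a methanesulfonyl group on the same nitrogen would bear on. They also leave open how an amide carbonyl on that nitrogen, or the free ring amine with its hydrogen, would compare with compound 3 in this assay.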